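The source may report more compounds than this note shows. Statements on the series, on what has been measured and on what is new or still open speak of the compounds shown alone.

Compound 1 `Cc1cc(-c2ccco2)c(S(C)(=O)=O)cc1C(=O)N=C(N)N` and compound 2 `Cc1cc(Oc2cccnc2)c(S(C)(=O)=O)cc1C(=O)N=C(N)N` share one core and differ only in the group carried on a single aromatic carbon. In a functional assay for inhibition of sodium/hydrogen exchanger (Oryctolagus cuniculus) (on this read-out higher numbers stand for weaker inhibition and lower numbers for stronger inhibition), compound 1 gives 16 nM, and in this assay compound 2 gives 8.8 nM. The change between them is a 1.8-fold lower number from compound 1 to compound 2 (0.26 log units; within the scatter). Compound 2 thus stands at the lowest of the two numbers shown, with compound 1 as its only neighbour, but since that gap lies within the scatter neither compound is set apart from the other.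

Compound 3 `Cc1cc(Oc2cncc(Cl)c2)c(S(C)(=O)=O)cc1C(=O)N=C(N)N` has not yet been measured in this assay. It differs from compound 2 by chloro in place of hydrogen on an aromatic carbon. Among the measured compounds shown here, the only measured step, a 1.8-fold lower number from compound 1 to compound 2 (0.26 log units; within the scatter), swaps one whole ring for another and so says nothing about placing a chloro on a ring that stays in place. For the measured compounds named here, with no step of this kind to lean on, compound 3 is expected to land close to compound 2, with no change beyond the scatter in either direction. The expected value for compound 3 in this assay is 8 nM, in a range from 3 nM to 22 nM. The expected step is a 1.1-fold lower number from compound 2 to compound 3 (0.04 log units; within the scatter).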

Compound 3, half-maximal inhibitory concentration: 14 nM
For compound 3 the middle estimate is 1.8-fold (0.24 log units) below the measured one; measured number inside the range.
By their numbers in this assay, from the lowest: compounds 2, 3 and 1 (each within the scatter of the next).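

In this assay, among the compounds shown here, this is the first step that keeps the ring in place and changes only a substituent on it: chloro in place of hydrogen, two atoms from the ring nitrogen, gives a 1.6-fold higher number from compound 2 to compound 3 (0.20 log units; within the scatter), so this ring carbon carries a chlorine atom with no difference that stands clear of the scatter. The larger swap, (5-chloropyridin-3-yl)oxy in place of furan-2-yl on the aromatic carbon of the shared core, gives a 1.1-fold lower number from compound 1 to compound 3 (0.06 log units; within the scatter), so the three groups tried at this place cannot be told apart on this read-out. No measurement is available that could explain these numbers, so the result stands as a plain observation.

As far as these compounds go, it remains open whether an amine, a methoxy group or a carboxylic acid on this same ring carbon would move the number beyond the scatter, and whether chloro on another carbon of the pyridine ring would behave like chloro here. For the compounds shown here, a single substituent gives only one step on this ring, so it cannot yet show a trend across different groups.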